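Anilide amides in the series: from compound 2 to compound 3

A few compounds are considered here, and "the series" means these few. Any claim that something is new, unique, unknown or untested is made for them only; others in the source may bear on it.

Measured in a functional assay on MDA-MB-231 cells (Homo sapiens) for cytotoxicity, read by MTT assay, with a stated time of 72 h; on this read-out higher numbers stand for weaker inhibition and lower numbers for stronger inhibition:
- compound 1 `COc1ccc(NC(=O)CN2CCN(c3nnc(Cc4ccncc4)c4ccccc34)CC2)cc1OC` gives 100 nM
- compound 2 `O=C(CN1CCN(c2nnc(Cc3ccncc3)c3ccccc23)CC1)Nc1cccc(F)c1` gives 4.4 nM

Compound 2, at 4.4 nM, holds the lower of the two numbers, and compound 1 lies beyond the scatter above it. The next compound, compound 3 `O=C(CN1CCN(c2nnc(Cc3ccncc3)c3ccccc23)CC1)Nc1ccc(F)c(C(F)(F)F)c1`, carries 4-fluoro-3-(trifluoromethyl)phenyl in place of 3-fluorophenyl on an amide-type nitrogen. The shared core stays unchanged.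

Going by the values given here, only one measured step bears on this change: a 23-fold lower number from compound 1 to compound 2 (1.36 log units; beyond the scatter). It is large and sits on the same amide-type nitrogen, so the group at this place can move the number strongly in this assay. Among the compounds with values here, that step replaced a different group, however, and the data hold no direct precedent for the group entering here. A small rise is therefore expected, probably not beyond the scatter, though a larger move in either direction remains possible. The expected change is a 1.8-fold higher number from compound 2 to compound 3 (0.26 log units; within the scatter). For compound 3 the estimated value is 8 nM, with an expected range from 1.5 nM to 40 nM.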

Compound 3, half-maximal inhibitory concentration: 1.9 nM
Estimate against measurement, compound 3: 4.2-fold (0.62 log units) above, and the stated range covers the measured number.
By their numbers in this assay, from the lowest: compound 3; then compound 2; then compound 1.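

In this assay the place on the amide-type nitrogen still has room below 3-fluorophenyl: 4-fluoro-3-(trifluoromethyl)phenyl gives a 2.3-fold lower number from compound 2 to compound 3 (0.36 log units; beyond the scatter) with a modest size of step, and the entering group holds 11 heavy atoms against 7 in the group it replaces. Set against 3,4-dimethoxyphenyl, the same group gives a 53-fold lower number from compound 1 to compound 3 (1.72 log units; beyond the scatter) as a large step, so both fluorine-bearing phenyl groups stand well under compound 1 and compound 3 now has the lowest number of the three. Nothing measured here accounts for these differences.

The compounds shown leave open whether 4-fluoro or 3-trifluoromethyl carries the step to compound 3, a question that plain phenyl, 3-(trifluoromethyl)phenyl and 4-fluorophenyl on the same amide-type nitrogen would separate. Also open, going by these compounds, is how far this place accepts anything other than a substituted phenyl, such as a benzyl group, a short alkyl chain, or a phenyl ring carrying an amine or a carboxylic acid.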